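Glucagon receptor antagonist series: methoxy to trifluoromethyl on aryl

This account rests on a few compounds, and the source may have more. Where it says the series, first, only, none or still open, it means among the compounds named here.

Measured compounds:
- compound 1, `CC(c1ccc(C(=O)NCCC(=O)O)cc1)n1nc(-c2cc(Cl)cc(Cl)c2)cc1-c1ccccc1C1CCCCC1`: 362 nM
- compound 2, `COc1cc(Cl)cc(-c2cc(-c3ccc4cc(OC)ccc4c3)n([C@@H](C)c3ccc(C(=O)NCCC(=O)O)cc3)n2)c1`: 67.9 nM
- compound 3, `O=C(O)CCNC(=O)c1ccc(Cn2nc(-c3cc(Cl)cc(Cl)c3)cc2-c2ccc3c(OC(F)(F)F)cccc3c2)cc1`: 114 nM

In a functional assay on CHO cells for antagonist activity at Glucagon receptor (Homo sapiens), read by scintillation counting and cAMP accumulation, with a stated time of 30 min (on this read-out higher numbers stand for weaker inhibition and lower numbers for stronger inhibition), compound 2 gives the lowest of the three numbers. Compound 3 lies within the scatter of compound 2, so no order between these two is claimed; compound 1 stands beyond the scatter and is weaker than compound 2.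

Compound 4, `COc1ccc2cc(-c3cc(-c4cc(Cl)cc(C(F)(F)F)c4)nn3[C@@H](C)c3ccc(C(=O)NCCC(=O)O)cc3)ccc2c1`, is not yet measured. It differs from compound 2 as follows: trifluoromethyl in place of methoxy on an aromatic carbon. Within the data shown here, no pair of measured compounds shows this same change, so no measured step is available to guide it. Compound 3 and compound 1 carry a dichlorophenyl at the same position and span a wide range of values, so the substituent pattern on this ring appears to matter, yet the direction for a trifluoromethyl is undetermined.

The expected step of a 1.1-fold higher number from compound 2 to compound 4 (0.04 log units; within the scatter) is none beyond the scatter. Compound 4 is estimated at 75 nM, with a range from 25 nM to 220 nM.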

Compound 4, half-maximal inhibitory concentration: 5.7 nM
Estimate against measurement, compound 4: 13-fold (1.12 log units) above, and the stated range ends above it.
By their numbers in this assay, from the lowest: compound 4; then compounds 2 and 3 (each within the scatter of the next); then compound 1.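

In this assay, the position meta to the chloro group on this aromatic ring proves highly sensitive: trifluoromethyl in place of methoxy gives a 12-fold lower number from compound 2 to compound 4 (1.08 log units; beyond the scatter). Among these compounds, this is the first single-place step, and it places compound 4 ahead of all three earlier compounds. No measurement shown accounts for the size of this step.

As far as these compounds go, it remains open whether a nitrile or a plain hydrogen at this position would give a number nearer compound 2 or compound 4. The compounds shown also do not establish whether this gain carries over to other substituents on the core.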